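A few compounds are considered here, and "the series" means these few. Any claim that something is new, unique, unknown or untested is made for them only; others in the source may bear on it.

Compound 1 `CC(=O)Nc1cccc(C2CCN(CCCn3c(-c4ccc(F)cc4)nc4ccccc43)CC2)c1` carries a fluorine on the outer benzene ring of the shared core. In an assay for displacement of a labelled ligand from melanin-concentrating hormone receptor 1 (Homo sapiens), read by fluorescence (a lower number here means a stronger inhibitor, a higher number a weaker inhibitor), compound 1 gives 56 nM. Compound 2 `CC(=O)Nc1cccc(C2CCN(CCCn3c(-c4ccc(C(C)C)cc4)nc4ccccc43)CC2)c1` has an isopropyl group at that same spot instead, and in this assay compound 2 gives 60 nM. Among the compounds with values here, the single comparison available, a 1.1-fold higher number from compound 1 to compound 2 (0.03 log units; within the scatter), shows that exchanging the small fluorine for the bulkier isopropyl group left the number essentially unchanged. Compound 2 therefore stands together with compound 1; the two numbers sit within the usual scatter of each other, so neither can be called stronger or weaker.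

Compound 3 `CC(=O)Nc1cccc(C2CCN(CCCn3c(-c4ccc(F)cc4Cl)nc4ccccc43)CC2)c1` is the next case. Its change from compound 2 is 2-chloro-4-fluorophenyl in place of 4-isopropylphenyl on an aromatic carbon. This brings back the fluorine of compound 1 and adds a chlorine on the same ring. Within the data shown here, the only measured step, a 1.1-fold higher number from compound 1 to compound 2 (0.03 log units; within the scatter), bears on it and was within the scatter, which suggests this ring tolerates variation. Among the measured compounds shown here, no measured step covers an added chlorine, so the added uncertainty is unquantified. Compound 3 is estimated to give about 55 nM, with a range from 20 nM to 160 nM. The estimate implies a step of a 1.1-fold lower number from compound 2 to compound 3 (0.04 log units; within the scatter).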

Compound 3, half-maximal inhibitory concentration: 4 nM
Compound 3: the middle estimate sits 14-fold (1.14 log units) above what was measured; the whole stated range lies above it.
By their numbers in this assay, from the lowest: compound 3; then compounds 1 and 2 (each within the scatter of the next).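

Within the data shown here, the clearest reading comes from the step of a 14-fold lower number from compound 1 to compound 3 (1.15 log units; beyond the scatter) in this assay, where the only change is chloro in place of hydrogen on an aromatic carbon of the outer ring. The earlier exchange of fluorine for isopropyl had left the number within the scatter, so that ring had looked tolerant of change, but this one added chlorine moves the number far beyond the scatter, which shows that the ring is not indifferent to what it carries. The step of a 15-fold lower number from compound 2 to compound 3 (1.18 log units; beyond the scatter) is of similar size and points the same way, although 2-chloro-4-fluorophenyl in place of 4-isopropylphenyl alters the ring in two places at once, while nothing available explains why the chlorine has so large an effect.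

The compounds shown leave open whether this drop in the number belongs to chlorine in particular or would also come with a bromine atom, a methyl group or a methoxy group on the same ring carbon. They also leave open whether chlorine would have the same effect alongside the isopropyl group of compound 2, or on a ring with no fluorine at all.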